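Formyl in Place of the Chloroethyl Chain

The source may report more compounds than this note shows. Statements on the series, on what has been measured and on what is new or still open speak of the compounds shown alone.

Measured compounds:
compound 1, `CCOCC1=CS(=O)(=O)c2ccccc2C1=O`, 92.4%
compound 2, `O=C1C(COCCBr)=CS(=O)(=O)c2ccccc21`, 100%
compound 3, `O=C1C(COCCCl)=CS(=O)(=O)c2ccccc21`, 98.1%

In a functional assay on the whole organism for inhibition, with Mus musculus as the target, at a dose of 10 mg/kg (a higher number here means more inhibition at the dose given (going by the name of the read-out), a lower number less inhibition), compound 3 gives 98.1%, the second highest of the three numbers. Its nearest step is a number 1.9 percentage points lower from compound 2 to compound 3 (within the scatter); its furthest is a number 5.7 percentage points higher from compound 1 to compound 3 (within the scatter).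

Compound 4, `O=COCC1=CS(=O)(=O)c2ccccc2C1=O`, differs from compound 3 in one place: formyl in place of 2-chloroethyl on an oxygen on a saturated carbon. Among the compounds with values here, no measured step exchanges the whole chain on that oxygen; the steps of a number 7.6 percentage points higher from compound 1 to compound 2 (within the scatter) and a number 5.7 percentage points higher from compound 1 to compound 3 (within the scatter) touch only the chain end, and every measured step lies within the scatter. Compound 1, with no halogen at all, gives 92.4%. Compound 4 is therefore expected to show no step beyond the scatter, a number 8.1 percentage points lower from compound 3 to compound 4 (within the scatter). The estimate for compound 4 is 90%, expected between 70% and 100%.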

Compound 4, a percentage reported as inhibition, in the whole organism at one dose (the size of the read-out at that dose, not a potency): 91.6%
Estimate against measurement, compound 4: 1.6 percentage points below, within the range that was stated.
By their numbers in this assay, from the lowest: compounds 4, 1, 3 and 2 (each within the scatter of the next).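

The exchange of the whole chain on the oxygen gives a number 6.5 percentage points lower from compound 3 to compound 4 (within the scatter) as well as a number 8.4 percentage points lower from compound 2 to compound 4 (within the scatter) and a number 0.8 percentage points lower from compound 1 to compound 4 (within the scatter) in this assay at this position. Formyl therefore stands on this oxygen with no separation from ethyl, 2-chloroethyl or 2-bromoethyl, so a change of the whole chain, like the earlier changes at its end, stays inside the scatter. Nothing measured here gives a reason for this. On these data alone, whether an amine, a carboxylic acid or a longer chain on this oxygen would separate from these four compounds stays open. A reading at a single dose also leaves their potency open.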